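A few compounds are considered here, and "the series" means these few. Any claim that something is new, unique, unknown or untested is made for them only; others in the source may bear on it.

Measured in an assay on isolated protein for inhibition of Aromatase (Homo sapiens), read by ELISA, using NADPH, with a stated time of 24 h; on this read-out higher numbers stand for weaker inhibition and lower numbers for stronger inhibition:
compound 1, `Fc1ccc(-c2[nH]c3cc(F)ccc3c2Cn2ccnc2)cc1`, gives 51.2 nM
compound 2, `Fc1ccc(-c2[nH]c3cc(F)ccc3c2Cn2cncn2)cc1`, gives 54.4 nM
compound 3, `COc1ccc(-c2[nH]c3cc(F)ccc3c2Cn2cncn2)cc1`, gives 14.1 nM

Compound 2 stands at the highest number of the three. Its nearest neighbour is compound 1, with a 1.1-fold higher number from compound 1 to compound 2 (0.03 log units; within the scatter), a gap within the scatter, so the two are not separated on this read-out. Its furthest is compound 3, with a 3.9-fold lower number from compound 2 to compound 3 (0.59 log units; beyond the scatter), a modest step beyond the scatter.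

Compound 4, `COc1ccc2c(Cn3cncn3)c(-c3ccc(F)cc3)[nH]c2c1`, is not yet measured. It differs from compound 2 in one place: methoxy in place of fluoro on an aromatic carbon. For the measured compounds named here, the only measured step that bears on this exchange is the same swap made on the pendant six-membered ring, a 3.9-fold lower number from compound 2 to compound 3 (0.59 log units; beyond the scatter). Going by the values given here, no measured pair exchanges any group on the fused system, and no pair shows whether a gain at one ring carries over to the other. A step in the same direction is therefore expected for compound 4, but a smaller one, with a wide range that reaches from a number near compound 3 up to no change beyond the scatter. The estimate for compound 4 in this assay is 32 nM, with a range from 11 nM to 90 nM. That estimate means an expected 1.7-fold lower number from compound 2 to compound 4 (0.23 log units; within the scatter).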

Compound 4, half-maximal inhibitory concentration: 238 nM
Estimate against measurement, compound 4: 7.4-fold (0.87 log units) below; the whole stated range lies below it.
By their numbers in this assay, from the lowest: compound 3; then compounds 1 and 2 (each within the scatter of the next); then compound 4.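

The exchange of fluoro for methoxy does not carry the same sign on both rings: on the six-membered ring of the fused system, the measurement in this assay gives (a 4.4-fold higher number from compound 2 to compound 4 (0.64 log units; beyond the scatter)), whereas on the other ring the same exchange gave (a 3.9-fold lower number from compound 2 to compound 3 (0.59 log units; beyond the scatter)). The effect of methoxy in this series therefore depends on where it sits, and the gain on the other ring cannot be used to predict a change on the fused system. Among the compounds shown, fluoro is favoured over methoxy at this position, a reading that rests on this single pair, and no available evidence explains the opposite directions of the two steps.

The compounds shown leave open whether the loss is specific to methoxy or would also appear with hydrogen, chloro, hydroxy or a longer ethoxy chain at the same carbon. Going by these compounds, it is also open whether the loss would persist with 1H-imidazol-1-yl in place of 1H-1,2,4-triazol-1-yl, or with methoxy on the other ring as well.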